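The source may report more compounds than this note shows. Statements on the series, on what has been measured and on what is new or still open speak of the compounds shown alone.

Measured compounds in a functional assay on HEK293 cells for agonist activity at Bombesin receptor subtype-3 (Mus musculus), read by luminescence and calcium flux, with a stated time of 10 min; on this read-out higher numbers stand for an effect only at larger amounts of compound and lower numbers for an effect already at smaller amounts:
compound 1 `CCC(C)(C)Cc1c[nH]c(CCc2ccc(-c3ccncc3)cc2)n1` gives 103 nM
compound 2 `CCC(C)(C)Cc1c[nH]c(CCc2ccc(-c3cnsc3)cc2)n1` gives 119 nM
compound 3 `CCC(C)(C)Cc1c[nH]c(CCc2ccc(-c3cccc(C#N)n3)cc2)n1` gives 115 nM

The three compounds share a core and differ only in the aromatic group on the carbon-only six-membered ring. Compound 3 holds the second highest of the three numbers, but its nearest neighbour, compound 2, lies a 1.0-fold lower number from compound 2 to compound 3 (0.01 log units; within the scatter), and compound 1 lies a 1.1-fold higher number from compound 1 to compound 3 (0.05 log units; within the scatter), so the three values cannot be told apart. The step of a 1.2-fold higher number from compound 1 to compound 2 (0.06 log units; within the scatter) is likewise within the scatter.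

Compound 4 `CCC(C)(C)Cc1c[nH]c(CCc2ccc(-c3cccnc3C(=O)O)cc2)n1` follows from compound 3 by the change (2-carboxypyridin-3-yl in place of 6-cyanopyridin-2-yl on an aromatic carbon). The ring changes its attachment and the nitrile gives way to a carboxy group, which brings one hydrogen-bond donor where the earlier group had none. Going by the values given here, all three measured steps bear on this position, and every one of them was within the scatter; none of them, however, introduces a hydrogen-bond donor or a carboxy group, so the series gives no direct precedent for this change.

On that basis a step of a 1.4-fold higher number from compound 3 to compound 4 (0.14 log units; within the scatter) is expected, not beyond the scatter, with a wider range than the measured steps alone would suggest. Compound 4 is estimated at 160 nM, between 60 nM and 500 nM in this assay.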

Compound 4, half-maximal effective concentration: 97 nM
Compound 4: middle estimate off by 1.6-fold (0.22 log units), on the high side, and the stated range covers the measured number.
By their numbers in this assay, from the lowest: compounds 4, 1, 3 and 2 (each within the scatter of the next).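

At this place on the six-membered aromatic ring of carbon only, para to a large group, the move to 2-carboxypyridin-3-yl changes nothing that this assay can resolve: a 1.2-fold lower number from compound 3 to compound 4 (0.07 log units; within the scatter) and a 1.2-fold lower number from compound 2 to compound 4 (0.09 log units; within the scatter) and a 1.1-fold lower number from compound 1 to compound 4 (0.03 log units; within the scatter) all lie within the usual scatter. The flat picture, until now drawn only from groups without a hydrogen-bond donor or a carboxy group, therefore also holds for a group that carries both, so the four compounds cannot be ranked. Nothing measured alongside these numbers offers an explanation for this insensitivity.

Compound 4 differs from compound 3 both in the attachment of the pyridine ring and in the exchange of nitrile for carboxy group, so the two changes cannot be separated here, and the methyl ester or primary amide of the same acid would be needed to say more about the carboxy group itself. All four groups are aromatic rings, which leaves open whether an aliphatic amine such as piperidine, a morpholine or a short alkyl chain at this place would move the number beyond the scatter.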